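A few compounds are considered here, and "the series" means these few. Any claim that something is new, unique, unknown or untested is made for them only; others in the source may bear on it.

Measured so far:
compound 1, `COc1ccc(Nc2cc(C3CCCCC3)oc(=O)c2)cc1`: 4.39 uM
compound 2, `Cc1ccc(Nc2cc(-c3ccccc3)oc(=O)c2)cc1`: 0.059 uM

In a functional assay on KBVIN cells (Homo sapiens) for cytotoxicity, read by MTT assay, with a stated time of 72 h (a higher number here means that more compound is needed for the effect, a lower number that less compound is needed), compound 1 gives 4.39 uM, the highest of the two numbers. Compound 2 gives 0.059 uM in this assay, a far lower number, and the gap between the two lies well beyond the scatter. Compound 2, however, differs from compound 1 in two places at once, so this pair says nothing about what any single change does.

Compound 3, `COc1ccc(Nc2cc(C3CCCC3)oc(=O)c2)cc1`, has not yet been measured. It differs from compound 1 in one place only: cyclopentyl in place of cyclohexyl on an aromatic carbon. Within the data shown here, no pair of measured compounds shows this kind of change, so there is no step on which to lean. With one carbon fewer in a saturated ring and no change in donors, acceptors or charge, a small step is expected, in no clear direction. The step of a 1.1-fold lower number from compound 1 to compound 3 (0.04 log units; within the scatter) is expected to stay within the scatter. Compound 3 is estimated to give about 4 uM in this assay, with a range from 1.5 uM to 12 uM.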

Compound 3, concentration for half-maximal effect: 4.98 uM
Compound 3: the middle estimate sits 1.2-fold (0.10 log units) below what was measured, and the stated range covers the measured number.
By their numbers in this assay, from the lowest: compound 2; then compounds 1 and 3 (each within the scatter of the next).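

Among these compounds, a single change, cyclopentyl in place of cyclohexyl, gives a 1.1-fold higher number from compound 1 to compound 3 (0.05 log units; within the scatter) in this assay, and this is the first step here that can be read at one position. On this aromatic carbon next to the ring oxygen, the two saturated carbon rings cannot be told apart in this assay, so going from the six-membered ring to the five-membered ring does not separate compound 1 from compound 3. Nothing available explains why the two rings behave alike, and this result shows only that they do.

As far as these compounds go, the much lower number of compound 2 remains unassigned, since it differs from compound 1 in two places, and the effect of a phenyl ring at this position with the methoxy group kept is still open. Also open, from the compounds shown here alone, is whether a group of another kind on this carbon, such as an amine or a longer open chain like n-butyl, would move the number beyond the scatter, or whether the position accepts such groups as readily as it accepts these two rings.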